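Carboxy in Place of Phenyl on the Shared Core

The source may report more compounds than this note shows. Statements on the series, on what has been measured and on what is new or still open speak of the compounds shown alone.

Compound 1 `O=C(COc1ccc(Cl)cc1)N1CCN(c2ncnc3sc(F)cc23)CC1`: 6350 nM
Compound 2 `O=C(COc1ccc(Cl)cc1)N1CCN(c2nc(-c3ccccc3)nc3sc(F)cc23)CC1`: > 10000 nM

In a functional assay on cells (Lymphocyte) (on this read-out higher numbers stand for weaker inhibition and lower numbers for stronger inhibition), compound 1 gives 6350 nM. Compound 2 reaches only the limit of this assay, > 10000 nM (the limit of > 10000 nM in this assay, at which 1 of the 2 values shown sits). For the measured compounds named here, the single measured step, an at least 1.5-fold higher number from compound 1 to compound 2 (0.19 log units; that floor lies within the scatter), is therefore at its floor within the scatter and shows no clear change. Compound 3 `O=C(O)c1nc(N2CCN(C(=O)COc3ccc(Cl)cc3)CC2)c2cc(F)sc2n1` differs from compound 2 by carboxy in place of phenyl on an aromatic carbon. Going by the values given here, no measured step involves a carboxy group at this place, so the available step offers no guide to direction. The expected change an at least 1.2-fold lower number from compound 2 to compound 3 (0.09 log units; that floor lies within the scatter) is small. Compound 3 is estimated at 8000 nM, within a range from 2000 nM to 30000 nM.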

Compound 3, half-maximal inhibitory concentration: > 10000 nM
Compound 3 gave a limit, no number; the forecaster's own chance of this, stated with the estimate: 50%; middle value at least 1.2-fold (0.09 log units) away from the limit.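

On this assay, compound 3 gives > 10000 nM, which is a limit and not a number. Carboxy in place of hydrogen at this position gives an at least 1.5-fold higher number from compound 1 to compound 3 (0.19 log units; that floor lies within the scatter), so carboxy, like phenyl, shows no sign of stronger inhibition here. The step between compound 2 and compound 3 cannot be read, because both sit at the same limit: the limit of > 10000 nM in this assay, at which 2 of the 3 values shown sit.

As far as these compounds go, how far past that limit compound 2 and compound 3 actually lie stays open. So does whether an amine or a methyl group at this position would give stronger inhibition than the hydrogen of compound 1.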